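Moving the Chlorine on the Triazole-Linked Phenyl Ring

A few compounds are considered here, and "the series" means these few. Any claim that something is new, unique, unknown or untested is made for them only; others in the source may bear on it.

Compound 1 `CC1(C)[C@H]2CC[C@]1(C)N(Cc1cn(-c3ccccc3Br)nn1)C(=O)C2` gives 140 nM in a functional assay on OVCAR-3 cells (Homo sapiens) for inhibition, read by MTT assay, with a stated time of 24 h; a lower number here means a stronger inhibitor, a higher number a weaker inhibitor.
Compound 2 `CC1(C)[C@H]2CC[C@]1(C)N(Cc1cn(-c3cccc(Cl)c3)nn1)C(=O)C2` gives 50 nM in this assay.
Compound 3 `Cc1ccccc1-n1cc(CN2C(=O)C[C@@H]3CC[C@@]2(C)C3(C)C)nn1` gives 150 nM in this assay.

All three share the same core and differ only in the substituted phenyl ring attached to the aromatic nitrogen. Among the three measured compounds, compound 2 has the lowest number, and both neighbours sit beyond the scatter from it: a 2.8-fold lower number from compound 1 to compound 2 (0.45 log units; beyond the scatter) and a 3.0-fold higher number from compound 2 to compound 3 (0.48 log units; beyond the scatter). The two compounds carrying a group next to the attachment point, compound 1 and compound 3, give values within the scatter of each other, as a 1.1-fold higher number from compound 1 to compound 3 (0.03 log units; within the scatter) shows.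

Compound 4 `CC1(C)[C@H]2CC[C@]1(C)N(Cc1cn(-c3ccc(Cl)cc3)nn1)C(=O)C2` has not been measured. It keeps the same atoms as compound 2, joined differently: 4-chlorophenyl in place of 3-chlorophenyl on an aromatic nitrogen. Within the data shown here, no measured step moves a chlorine between these two places on the phenyl ring, so the closest guidance is that changing where the phenyl ring carries its group changed the value modestly in both earlier steps. Compound 4 is therefore expected to stay fairly close to compound 2, with a modest weakening considered possible, giving an estimated step of a 1.6-fold higher number from compound 2 to compound 4 (0.20 log units; within the scatter). The estimate for compound 4 in this assay is 80 nM, within a range from 30 nM to 250 nM.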

Compound 4, half-maximal inhibitory concentration: 160 nM
Compound 4: the middle estimate sits 2.0-fold (0.30 log units) below what was measured, and the stated range covers the measured number.
By their numbers in this assay, from the lowest: compound 2; then compounds 1, 3 and 4 (each within the scatter of the next).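

In this assay, moving the chlorine is enough on its own to change the result, with the atoms of the group staying the same: there is a 3.2-fold higher number from compound 2 to compound 4 (0.51 log units; beyond the scatter) here, so 3-chlorophenyl and 4-chlorophenyl cannot be treated as equivalent at this position. Compound 4 also joins the two other compounds, with a 1.1-fold higher number from compound 3 to compound 4 (0.03 log units; within the scatter) and a 1.1-fold higher number from compound 1 to compound 4 (0.06 log units; within the scatter) both printed as within the scatter, so of the four groups only the 3-chlorophenyl of compound 2 stands apart, while 4-chlorophenyl, 2-bromophenyl and 2-methylphenyl cannot be told apart. No measurement at hand explains the difference between the two chlorine placements.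

The compounds shown leave open whether the lower number of compound 2 belongs to chlorine itself or to any group placed where its chlorine sits, a question that 3-bromophenyl or 3-methylphenyl would address. They also leave open how an unsubstituted phenyl, or a phenyl carrying an amine or a carboxylic acid, would compare with these four at the same position.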